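This account rests on a few compounds, and the source may have more. Where it says the series, first, only, none or still open, it means among the compounds named here.

In a functional assay on A-375 cells (Homo sapiens) for inhibition, read by CCK-8 assay, with a stated time of 72 h, tested at 2 uM (a higher number here means more inhibition of growth at the concentration tested, a lower number less inhibition of growth), compound 2 `Nc1ccccc1NC(=O)/C=C/c1ccc(CSc2ccc(Cl)cc2)cc1` gives 13.4%. That number lies within the usual scatter of compound 3 `CCc1ccc(SCc2ccc(C(=O)Nc3ccccc3N)cc2)cc1`, which gives 19.6%, and well short of compound 1 `COc1ccc(SCc2ccc(/C=C/C(=O)Nc3ccccc3N)cc2)cc1OC`, which gives 46%. Compound 4 `Nc1ccccc1NC(=O)/C=C/c1ccc(CSc2ccc(F)cc2)cc1` differs from compound 2 in a single place: fluoro in place of chloro on an aromatic carbon.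

Going by the values given here, only one measured step touches this part of the structure: a number 32.6 percentage points lower from compound 1 to compound 2 (beyond the scatter), where 4-chlorophenyl took the place of 3,4-dimethoxyphenyl on a sulfur. That step was large and beyond the scatter, but it exchanged a whole substituted phenyl group, whereas here fluoro simply takes the place of chloro. Among the compounds with values here, no measured pair compares fluoro with chloro directly, so the large step is a poor guide to the size of this one. A small change is expected, with only a weak lean upward, and the estimated a number 4.6 percentage points higher from compound 2 to compound 4 (within the scatter) stays within the scatter. In this assay, the estimate for compound 4 is 18%, with an expected range of 5% to 38%.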

Compound 4, percent growth inhibition at one concentration: 28.8%
For compound 4 the middle estimate is 10.8 percentage points below the measured one, within the range that was stated.
By their numbers in this assay, from the lowest: compounds 2, 3 and 4 (each within the scatter of the next, the first and the last beyond it); then compound 1.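

In this assay fluoro in place of chloro gives a number 15.4 percentage points higher from compound 2 to compound 4 (beyond the scatter) and so shows that the identity of this single atom on the 4-substituted phenyl ring matters, something the earlier exchange of a whole substituted phenyl group could not separate out. The 3,4-dimethoxyphenyl group still stands apart, with a number 17.2 percentage points lower from compound 1 to compound 4 (beyond the scatter), so fluoro closes only part of the gap between the chloro compound and compound 1. No measurement at hand explains why fluoro and chloro differ at this place.

The compounds shown leave open how bromo, methyl or a single methoxy at this place would compare with fluoro and chloro. From the compounds shown here alone, it also remains open whether the higher number of compound 1 depends on one of its methoxy groups or on both.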